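The source may hold more compounds than are shown below. What is called first, only, known or untested is meant among the compounds shown, and "the series" means these compounds.

Compound 1, with the structure `CCOCCOC(=O)C(=O)Nc1nc(-c2cc(Cl)no2)cs1`, was tested in a functional assay on the whole organism with Rattus norvegicus as the target; on this read-out higher numbers stand for an effect only at larger amounts of compound and lower numbers for an effect already at smaller amounts. In this assay compound 1 reaches only the limit > 30 mg/kg, so no number is known for it. Compound 2, with the structure `CCOCCOC(=O)C(=O)Nc1nc(-c2cc(C)on2)cs1`, gives 2 mg/kg in this assay. The step of an at least 15-fold lower number from compound 1 to compound 2 (1.17 log units; beyond the scatter) goes with the change in the core (5-methyl-1,2-oxazol-3-yl in place of 3-chloro-1,2-oxazol-5-yl on an aromatic carbon).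

Compound 3, with the structure `O=C(O)C(=O)Nc1nc(-c2cc(Cl)no2)cs1`, again sits at a limit in this assay, > 30 mg/kg. The change from compound 1 to compound 3 is hydrogen in place of 2-ethoxyethyl on an oxygen next to a carbonyl group, and the step that the two limits leave unreadable from compound 1 to compound 3 cannot be sized because of the limit of > 30 mg/kg in this assay, at which 2 of the 3 values shown sit.

Compound 4, with the structure `Cc1cc(-c2csc(NC(=O)C(=O)O)n2)no1`, carries the same change relative to compound 2, namely (hydrogen in place of 2-ethoxyethyl on an oxygen next to a carbonyl group), on a place described in the same words. Since the measured pair of compound 1 and compound 3 leaves the size of this step unreadable, the expectation for compound 4 rests mainly on the measured value of compound 2. In this assay compound 2 gives 2 mg/kg. The step from compound 2 to compound 4 is expected to be a 4.0-fold higher number from compound 2 to compound 4 (0.60 log units; beyond the scatter). Compound 4 is therefore estimated at 8 mg/kg, with a likely range from 2 mg/kg to 30 mg/kg.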

Compound 4, dose for half-maximal effect: 17 mg/kg
For compound 4 the middle estimate is 2.1-fold (0.33 log units) below the measured one; low and high end bracket the measured number.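

On the core carrying 5-methyl-1,2-oxazol-3-yl, putting hydrogen in place of 2-ethoxyethyl on an oxygen next to a carbonyl group gives, in this assay, an 8.5-fold higher number from compound 2 to compound 4 (0.93 log units; beyond the scatter). The same change on the core carrying 3-chloro-1,2-oxazol-5-yl, from compound 1 to compound 3, cannot be read, because both compounds stand at a limit and not at a number: the limit of > 30 mg/kg in this assay, at which 2 of the 4 values shown sit.

The size of this change is therefore known on one core only, and the compounds shown do not tell whether it carries over to the other core in size or even in direction.

On these data alone, it remains open how a smaller group such as ethyl or methyl on the same oxygen would read in this assay on either core. Also open, as far as these compounds go, is how an amide, with an amine in place of the 2-ethoxyethoxy or hydroxy group, would compare with the ester of compound 2 and the carboxylic acid of compound 4.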